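The source may report more compounds than this note shows. Statements on the series, on what has been measured and on what is new or still open speak of the compounds shown alone.

Series notes. Compound 1 `Cc1ccc(-c2ccc(C)n2-c2ccc(-c3nc4ccc(F)cc4s3)cc2)cc1` gives 2970 nM in a functional assay on MCF7 cells (Homo sapiens) for cytotoxicity, read by MTT assay, with a stated time of 72 h; a higher number here means a weaker inhibitor, a lower number a stronger inhibitor. Compound 2 `COc1ccc2nc(-c3ccc(-n4c(C)ccc4-c4ccc(C)cc4)cc3)sc2c1` gives 2850 nM, and compound 3 `COc1ccc2nc(-c3ccc(-n4c(C)ccc4-c4ccc(F)cc4)cc3)sc2c1` gives 2800 nM. The change from compound 1 to compound 2, (methoxy in place of fluoro on an aromatic carbon), brought a 1.0-fold lower number from compound 1 to compound 2 (0.02 log units; within the scatter); the next change brought a 1.0-fold lower number from compound 2 to compound 3 (0.01 log units; within the scatter). The difference between the core of compound 1 and the core of compound 3 is not broken down here.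

Compound 4 `COc1ccc(-c2ccc(C)n2-c2ccc(-c3nc4ccc(OC)cc4s3)cc2)cc1` is not yet measured; it differs from compound 3 by methoxy in place of fluoro on an aromatic carbon. This is the same kind of change as from compound 1 to compound 2, but there the place was part of a fused or bridged system of two rings, meta to a fused ring and para to a fused ring, while here it is para to a large group. Because a 1.0-fold lower number from compound 1 to compound 2 (0.02 log units; within the scatter) lay within the scatter, the expected step is no change at the digits printed from compound 3 to compound 4 (within the scatter). Compound 4 is estimated at 2800 nM, between 1500 nM and 5500 nM.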

Compound 4, half-maximal inhibitory concentration: 4830 nM
For compound 4 the middle estimate is 1.7-fold (0.24 log units) below the measured one; the measured number falls inside the stated range.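

In this assay, methoxy in place of fluoro gives a 1.7-fold higher number from compound 3 to compound 4 (0.24 log units; within the scatter), and methoxy in place of methyl at the same place gives a 1.7-fold higher number from compound 2 to compound 4 (0.23 log units; within the scatter). Methoxy in place of fluoro shows no difference between the two cores that can be told from the scatter: the same change on two cores in this assay, a 1.0-fold lower number (0.02 log units; within the scatter) from compound 1 to compound 2 and a 1.7-fold higher number (0.24 log units; within the scatter) from compound 3 to compound 4, 1.8-fold (0.25 log units) apart, within the scatter of two such steps. For the compounds shown here, this shows only that these two pairs do not separate; it does not show that the step is the same on both cores or that it would carry to any other core.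

The compounds shown carry only fluoro, methyl and methoxy at these places. Going by these compounds, whether an amine, a carboxylic acid or a longer chain in place of the methoxy of the 4-methoxyphenyl group would shift this assay beyond the scatter remains open.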